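Swapping the Cyclohexyl for 4-Fluorophenyl in a Sulfonamide Amide

The source may report more compounds than this note shows. Statements on the series, on what has been measured and on what is new or still open speak of the compounds shown alone.

Compound 1 `CS(=O)(=O)Nc1ccc(C(C(=O)NCc2ccc(C(F)(F)F)nc2SC2CCCCC2)C2CCCC2)cc1F` is tested in an assay on CHO cells for antagonist activity at transient receptor potential cation channel subfamily V member 1 (Homo sapiens), read by FLIPR (a lower number here means a stronger inhibitor, a higher number a weaker inhibitor), and gives 103 nM. Compound 2 `CS(=O)(=O)Nc1ccc(C(C(=O)NCc2ccc(C(F)(F)F)nc2SC2CCCCC2)C2CCCCC2)cc1F` carries a cyclohexyl in the same place; in this assay compound 2 is reported as "active" (no number reported), so no number stands for it and its position relative to compound 1 cannot be ranked. Compound 3 `CS(=O)(=O)Nc1ccc(C(C(=O)NCc2ccc(C(F)(F)F)nc2SC2CCCCC2)c2ccc(F)cc2)cc1F` differs from compound 2 by 4-fluorophenyl in place of cyclohexyl on a saturated chain carbon bound to an aromatic carbon and a carbonyl carbon. Given the single number from compound 1, the step to compound 3 is expected to stay within the usual scatter, with no clear direction. Compound 3 is therefore estimated at 150 nM, in a range from 30 nM to 800 nM.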

Compound 3, inhibition constant: 37.6 nM
For compound 3 the middle estimate is 4.0-fold (0.60 log units) above the measured one; the range from low to high includes it.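

In this assay, the saturated chain carbon bound to an aromatic carbon and a carbonyl carbon accepts an aromatic ring: 4-fluorophenyl in place of cyclopentyl gives a 2.7-fold lower number from compound 1 to compound 3 (0.44 log units; beyond the scatter), a step beyond the scatter. The change from cyclohexyl to 4-fluorophenyl itself cannot be read, as compound 2 has no number. Nothing available explains why the aromatic ring gives the stronger inhibitor.

As far as these compounds go, what a plain phenyl or a pyridyl would give at this carbon remains open, as does whether the fluorine has any part in the step.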